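This account rests on a few compounds, and the source may have more. Where it says the series, first, only, none or still open, it means among the compounds named here.

Values in a functional assay on NCI-H1650 cells (Homo sapiens) for cytotoxicity, read by MTT assay, with a stated time of 72 h; a higher number here means a weaker inhibitor, a lower number a stronger inhibitor:
- compound 1 `COc1cc(/C=C2\CN(C)C/C(=C\c3cc(OC)c(OC)c(OC)c3)C2=O)cc(OC)c1OC`: 1500 nM
- compound 2 `CCN1C/C(=C\c2cc(OC)c(OC)c(OC)c2)C(=O)/C(=C/c2cc(OC)c(OC)c(OC)c2)C1`: 8200 nM
- compound 3 `CCN1C/C(=C\c2ccc(OC)c(OC)c2)C(=O)/C(=C/c2ccc(OC)c(OC)c2)C1`: 12000 nM

Compound 2 at 8200 nM lies within the scatter of compound 3 at 12000 nM. Compound 1 at 1500 nM gives a clearly lower number.

The next comparison is compound 4 `CCC(=O)N1C/C(=C\c2cc(OC)c(OC)c(OC)c2)C(=O)/C(=C/c2cc(OC)c(OC)c(OC)c2)C1`, which has propanoyl in place of ethyl on an amine nitrogen in a ring.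

Within the data shown here, only one measured step bears on this change: methyl in place of hydrogen on a saturated chain carbon bound to an amine nitrogen in a ring, which gives a 5.5-fold higher number from compound 1 to compound 2 (0.74 log units; beyond the scatter). That modest step shows that the number in this assay can respond to a small change at this part of the core. Among the measured compounds shown here, no measured compound has a propanoyl group, so neither the size nor the direction of the new step is established. A modest step towards a lower number is expected, with wide uncertainty in either direction.

The expected change is a 2.3-fold lower number from compound 2 to compound 4 (0.37 log units; beyond the scatter).

For compound 4 the estimated value is 3500 nM, with an expected range of 900 nM to 14000 nM.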

Compound 4, half-maximal inhibitory concentration: 4400 nM
Beside the measured number, compound 4's estimate is 1.3-fold (0.10 log units) below it; the range from low to high includes it.
By their numbers in this assay, from the lowest: compound 1; then compounds 4, 2 and 3 (each within the scatter of the next, the first and the last beyond it).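

In this assay, among these compounds, propanoyl in place of ethyl on the amine nitrogen in a ring gives a 1.9-fold lower number from compound 2 to compound 4 (0.27 log units; within the scatter), so this position accepts a carbonyl-bearing group with no step that can be told from the scatter. Propanoyl in place of methyl gives a 2.9-fold higher number from compound 1 to compound 4 (0.47 log units; beyond the scatter), so compound 1 with its methyl stays apart from compound 4 as it does from compound 2, and two different groups now give steps in the same direction from compound 1. Nothing available explains these steps.

Going by these compounds, what a hydrogen, an acetyl, a benzoyl or a longer alkyl chain on this nitrogen would give remains open. Also open, on these data alone, is whether propanoyl gives a similar result with the aryl groups of compound 3 in place of those of compound 2.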